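Heteroaryl sulfonamide variation on a diterpenoid ester scaffold

The compounds below may be only part of what the source reports. "The series", "measured", "known", "first", "only" and "open" are said of these compounds alone.

Among the compounds with values here, compound 2 `C=C1CC[C@@H]2[C@](C)(COC(C)=O)[C@H](OC(C)=O)CC[C@@]2(C)[C@H]1CC(Nc1ccc(S(=O)(=O)Nc2ccc(Cl)nn2)cc1)C1=CCOC1=O` holds the lowest of the two numbers so far in a functional assay on COLO 205 cells (Homo sapiens) for inhibition, read by sulforhodamine B assay, with a stated time of 48 h; a lower number here means that less compound is tolerated, a higher number that more compound is tolerated: compound 2 gives 6860 nM. Its nearest neighbour is compound 1 `C=C1CC[C@@H]2[C@](C)(COC(C)=O)[C@H](OC(C)=O)CC[C@@]2(C)[C@H]1CC(Nc1ccc(S(=O)(=O)Nc2nccs2)cc1)C1=CCOC1=O`, which in this assay gives 48900 nM. Within the data shown here, the single measured step, a 7.1-fold lower number from compound 1 to compound 2 (0.85 log units; beyond the scatter), is the one that separates them, and it is the only step available for comparison.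

Compound 3 `C=C1CC[C@@H]2[C@](C)(COC(C)=O)[C@H](OC(C)=O)CC[C@@]2(C)[C@H]1CC(Nc1ccc(S(=O)(=O)Nc2ncccn2)cc1)C1=CCOC1=O` differs from compound 2 in one place: pyrimidin-2-yl in place of 6-chloropyridazin-3-yl on a sulfonamide nitrogen. The measured step bears on this change only indirectly: it also exchanges one heteroaryl ring for another on the same sulfonamide nitrogen, and it shows that such an exchange can move the number by a 7.1-fold lower number from compound 1 to compound 2 (0.85 log units; beyond the scatter). Among the measured compounds shown here, no measured pair compares two six-membered rings, and no pair isolates the chlorine from the ring itself, so the expectation leans on the observation that the chlorinated ring gave the lower number. The expected step is therefore a 2.3-fold higher number from compound 2 to compound 3 (0.37 log units; beyond the scatter), towards a higher number, beyond the scatter but smaller than the measured step. For compound 3 the estimate in this assay is 16000 nM, with a range of 5000 nM to 50000 nM.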

Compound 3, concentration lethal to 50% of the cells: 8110 nM
Estimate against measurement, compound 3: 2.0-fold (0.30 log units) above; the measured number falls inside the stated range.
By their numbers in this assay, from the lowest: compounds 2 and 3 (each within the scatter of the next); then compound 1.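

In this assay, pyrimidin-2-yl in place of 6-chloropyridazin-3-yl on a sulfonamide nitrogen gives a 1.2-fold higher number from compound 2 to compound 3 (0.07 log units; within the scatter), so these two six-membered aromatic rings cannot be told apart at this position, and the chlorine is not required for a number in the range of compound 2. The comparison with the thiazole now has a second member, a 6.0-fold lower number from compound 1 to compound 3 (0.78 log units; beyond the scatter), which places 1,3-thiazol-2-yl apart from both six-membered rings among the three compounds shown, with no compound going against this. Nothing measured on these groups accounts for that separation.

The compounds shown leave open whether the sulfonamide nitrogen needs an aromatic ring at all, which an acetyl group or a plain hydrogen there would test, and whether pyridin-2-yl would fall with compounds 2 and 3. Also open, from the compounds shown here alone, is whether another ring of the thiazole kind, such as 1,3-oxazol-2-yl, would sit with compound 1 or with compounds 2 and 3, which would show whether the separation belongs to the thiazole alone.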